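Tolerated Concentrations in a Small Alkynyl Series

A few compounds are considered here, and "the series" means these few. Any claim that something is new, unique, unknown or untested is made for them only; others in the source may bear on it.

Measured compounds:
Compound 1 `CCCCC#Cc1cc2cn([C@@H]3O[C@H](CO)[C@@H](O)[C@H]3O)c(=O)nc2o1`: in a functional assay on HEL cells (Homo sapiens) for cytotoxicity (a lower number here means that less compound is tolerated, a higher number that more compound is tolerated), compound 1 gives > 144000 nM, which is a limit of the assay and not a number.
Compound 2 `CCCCC#Cc1cc2cn(C)c(=O)nc2o1`: compound 2 gives >= 217000 nM, again a limit of the assay.
Compound 3 `CCCCCCCCCCC#Cc1cc2cn(C)c(=O)nc2o1`: compound 3 gives > 150000 nM, also a limit of the assay.

Compound 3 therefore stands nowhere on a scale; it sits at a limit, as do the other two values shown (the limit of > 144000 nM in this assay, at which 1 of the 3 values shown sits, (the limit of > 150000 nM in this assay, at which 1 of the 3 values shown sits), (the limit of >= 217000 nM in this assay, at which 1 of the 3 values shown sits)). Among the compounds with values here, the only single-point step between measured compounds, a step that the two limits leave unreadable from compound 2 to compound 3, cannot be sized, since both ends are limits. Compound 1 and compound 2 differ at the aromatic nitrogen, but as both values are limits no step can be read between them either.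

The change from compound 3 to compound 4 `CCCCCCCCCCC#Cc1cc2cn([C@@H]3O[C@H](CO)[C@@H](O)[C@@H]3O)c(=O)nc2o1` is 3,4-dihydroxy-5-(hydroxymethyl)oxolan-2-yl in place of methyl on an aromatic nitrogen. Within the data shown here, no measured step bears on this change in a readable way. What the three values do show is that none of the compounds, sugar-bearing or methyl-bearing, short chain or long chain, reached a cytotoxic concentration within the tested range. On that basis no step beyond the scatter is expected in this assay, in either direction: the expected step of a number no higher from compound 3 to compound 4 (the limit leaves the size open) is essentially nil. Compound 4 is estimated at 150000 nM, within 70000 nM to 300000 nM, most probably reported again only as a limit.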

Compound 4, minimum cytotoxic concentration: 46000 nM
Beside the measured number, compound 4's estimate is 3.3-fold (0.51 log units) above it; the measured number lies below the stated range.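

In this assay, within the data shown here, the change at the aromatic nitrogen, with 3,4-dihydroxy-5-(hydroxymethyl)oxolan-2-yl in place of methyl, gives an at least 3.2-fold lower number from compound 3 to compound 4 (0.51 log units; beyond the scatter), the only step that can be read, and compound 4 is the only one of the four compounds with a number rather than a limit. This shows that, with the long chain in place, the group on this nitrogen can lower the tolerated concentration in this assay, which the other steps could not show, as those between limits cannot be read. No measured information shown here gives a cause for this step.

Going by these compounds, compound 3 gives > 150000 nM, which is a limit, so the full size of the step stays open, and the step is read with the long chain only, so the same change on a shorter chain remains unsized. Also open, on these data alone, is whether a smaller group on this nitrogen, such as ethyl or 2-hydroxyethyl, or an amine or a carboxylic acid at the far end of the chain, would move the tolerated concentration in this assay.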